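The compounds below may be only part of what the source reports. "The series", "measured", "known", "first", "only" and "open" are said of these compounds alone.

Measured compounds in an ADME assay on microsomes from liver (Homo sapiens) for pharmacokinetics, read by LC-MS, with a stated time of 60 min, tested at 1 uM; a lower number here means slower removal, a higher number faster removal of the compound:
compound 1 `O=C(NCc1ccc(S(=O)(=O)c2ccccc2)cc1)N1Cc2ccncc2C1` gives 7.5 mL/min/kg;
compound 2 `CN1CCC(S(=O)(=O)c2ccc(CNC(=O)N3Cc4ccncc4C3)cc2)CC1` gives 11 mL/min/kg;
compound 3 `O=C(NCc1ccc(S(=O)(=O)N2CC3(CCOCC3)C2)cc1)N1Cc2ccncc2C1` gives 13 mL/min/kg.

Compound 1 has the lowest of the three numbers, but its gaps to compound 2 and compound 3 both fall within the scatter, so no order among the three can be claimed. Compound 4 `O=C(NCc1ccc(S(=O)(=O)N2CCC(N3CCCC3)CC2)cc1)N1Cc2ccncc2C1` is not yet measured. It differs from compound 1 in one place: 4-(pyrrolidin-1-yl)piperidin-1-yl in place of phenyl on a sulfonyl sulfur. Among the measured compounds shown here, two measured steps bear on this kind of change at the sulfonyl sulfur: a 1.5-fold higher number from compound 1 to compound 2 (0.17 log units; within the scatter) and a 1.7-fold higher number from compound 1 to compound 3 (0.24 log units; within the scatter), both within the scatter. On that basis, compound 4 is expected to show no step beyond the scatter, a 1.5-fold higher number from compound 1 to compound 4 (0.17 log units; within the scatter), and its estimated value in this assay is 11 mL/min/kg, within a range from 6 mL/min/kg to 20 mL/min/kg.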

Compound 4, clearance: 6 mL/min/kg
For compound 4 the middle estimate is 1.8-fold (0.26 log units) above the measured one; measured number inside the range.
By their numbers in this assay, from the lowest: compounds 4, 1, 2 and 3 (each within the scatter of the next, the first and the last beyond it).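

In this assay, among the compounds shown here, the 4-(pyrrolidin-1-yl)piperidin-1-yl group gives the first step at the sulfonyl sulfur that lies beyond the scatter, a modest one: a 2.2-fold lower number from compound 3 to compound 4 (0.34 log units; beyond the scatter) against the group of 9 heavy atoms. The steps of a 1.3-fold lower number from compound 1 to compound 4 (0.10 log units; within the scatter) and a 1.8-fold lower number from compound 2 to compound 4 (0.26 log units; within the scatter) stay within the scatter, so this larger group on the sulfonyl sulfur cannot be told apart from phenyl or from 1-methylpiperidin-4-yl. Nothing at hand explains the result. The compounds shown leave open how a plain piperidin-1-yl or a morpholin-4-yl would read at this place, and so whether the pyrrolidine ring matters.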